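The source may report more compounds than this note shows. Statements on the series, on what has been measured and on what is new or still open speak of the compounds shown alone.

Working notes on the series in an ADME assay on HEL cells (Homo sapiens) for cytotoxicity, with a stated time of 3 days; a higher number here means that more compound is tolerated, a lower number that less compound is tolerated.

Compound 3 `CCC1(Cc2ccccc2)OS(=O)(=O)C=C1OCCc1ccccc1` gives 48000 nM in this assay. This is the lowest of the two numbers shown, yet its nearest neighbour, compound 2 `CCC1(Cc2ccccc2)OS(=O)(=O)C=C1OCc1cccc(Cl)c1` with 50000 nM, sits a 1.0-fold lower number from compound 2 to compound 3 (0.02 log units; within the scatter) away, so the two cannot be ordered. Compound 1 `CCC1(Cc2ccccc2)OS(=O)(=O)C=C1OC` gives only a limit of the assay, > 200000 nM. The steps from compound 1 are an at least 4.0-fold lower number from compound 1 to compound 2 (0.60 log units; beyond the scatter) and an at least 4.1-fold lower number from compound 1 to compound 3 (0.61 log units; beyond the scatter); both rest on (the limit of > 200000 nM in this assay, at which 1 of the 3 values shown sits).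

Compound 4 `CCC1(Cc2ccccc2)OS(=O)(=O)C=C1OC(=O)c1ccccc1` differs from compound 3 in one place: benzoyl in place of phenethyl on an oxygen on an unsaturated carbon. Among the measured compounds shown here, no measured step exchanges one aromatic-bearing group on this oxygen for another of a different link; the only comparison among such groups, a 1.0-fold lower number from compound 2 to compound 3 (0.02 log units; within the scatter), lies within the scatter, and the two larger steps concern hydrogen giving way to an aromatic-bearing group, not an exchange between two of them. On this footing no step beyond the scatter is expected from compound 3 to compound 4, and the estimated step is a 1.0-fold higher number from compound 3 to compound 4 (0.02 log units; within the scatter). Compound 4 is therefore expected to give about 50000 nM in this assay, with a range from 20000 nM to 150000 nM.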

Compound 4, half-maximal cytotoxic concentration: > 200000 nM
Compound 4 gave a limit, no number; the forecaster's own chance of this, stated with the estimate: 20%; middle value at least 4.0-fold (0.60 log units) away from the limit.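

Exchanging one aromatic-bearing group for another on this oxygen can move the number beyond the scatter in this assay: benzoyl gives (an at least 4.1-fold higher number from compound 3 to compound 4 (0.61 log units; beyond the scatter)) against phenethyl and (an at least 4.0-fold higher number from compound 2 to compound 4 (0.60 log units; beyond the scatter)) against 3-chlorobenzyl, whereas the exchange between those two groups stayed within the scatter. Benzoyl and phenethyl each carry one six-membered aromatic ring and differ in the carbonyl of benzoyl, so an aromatic ring on this oxygen does not by itself go with the lower number. Compound 4 shares with compound 1 a limit rather than a number, so the step between them cannot be read, and the two readable steps are minimum sizes resting on that limit: the limit of > 200000 nM in this assay, at which 2 of the 4 values shown sit.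

Whether the carbonyl alone accounts for the change remains open, as an unsubstituted benzyl and an acetyl on this oxygen are not among the compounds shown. Also open, from the compounds shown here alone, is whether a phenylcarbamoyl group at the same place would follow benzoyl or the groups of compound 2 and compound 3.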